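The source may report more compounds than this note shows. Statements on the series, on what has been measured and on what is new or still open speak of the compounds shown alone.

In an ADME assay (liver) for metabolic stability, with Liver microsome (Homo sapiens) as the target, read by LC-MS, using microsomes and NADPH, with a stated time of 5 min, at 37 degrees C (a higher number here means faster removal of the compound, a lower number slower removal), compound 1 (`CCn1c([C@@H](C)NS(=O)(=O)c2ccc(Cl)cc2)nc2cc(C(N)=O)ccc21`) gives < 5 mL.min-1.g-1, which is a limit and not a number. Compound 2 (`CCn1c([C@@H](C)NS(=O)(=O)c2ccc(Cl)cc2)nc2ccc(S(C)(=O)=O)cc21`) also gives a limit, < 5 mL.min-1.g-1. Compound 3 (`CCn1c([C@@H](C)NS(=O)(=O)C2CC2)nc2ccc(C(F)(F)F)cc21`) likewise stands only at a limit, < 3 mL.min-1.g-1. No two of these compounds differ in just one place. Compound 4 (`CCn1c([C@@H](C)NS(=O)(=O)c2ccc(C#N)cc2)nc2ccc(C(F)(F)F)cc21`) has 4-cyanophenyl in place of cyclopropyl on a sulfonyl sulfur. Compound 2, at the limit < 5 mL.min-1.g-1, also has a six-membered aromatic ring of carbon only on its sulfonyl sulfur, so only a small change is expected. The expected step of an at least 2.0-fold higher number from compound 3 to compound 4 (0.30 log units; that floor lies within the scatter) is a modest rise in this assay. For compound 4 the estimated value is 6 mL.min-1.g-1, with an expected range from 3 mL.min-1.g-1 to 15 mL.min-1.g-1.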

Compound 4, intrinsic clearance in microsomes: 34 mL.min-1.g-1
Compound 4: middle estimate off by 5.7-fold (0.75 log units), on the low side; the whole stated range lies below it.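

On the sulfonyl sulfur, this position is not indifferent to what sits there: in this assay, 4-cyanophenyl in place of cyclopropyl gives an at least 11-fold higher number from compound 3 to compound 4 (1.05 log units; beyond the scatter) with the rest of the molecule unchanged. On these data alone, for compound 3 the value < 3 mL.min-1.g-1 is a limit and not a number, and the true size of the step stays unknown. As far as these compounds go, whether the rise belongs to the six-membered aromatic ring or to its nitrile remains open. A plain phenyl or a straight propyl chain on the same sulfur would separate these possibilities.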